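A few compounds are considered here, and "the series" means these few. Any claim that something is new, unique, unknown or untested is made for them only; others in the source may bear on it.

Compounds measured in a functional assay on SUP-B15 cells (Homo sapiens) for antiproliferative activity, with a stated time of 72 h; a higher number here means that more compound is needed for the effect, a lower number that less compound is needed:
compound 1, `COC(=O)c1cc(=O)c2c(OC)cc(OC)cc2[nH]1`: 16100 nM
compound 2, `COC(=O)c1cc(=O)c2c(OC)cc(OC)cc2n1C`: > 37900 nM; this is a limit of the assay, not a number
compound 3, `COc1ccc(-c2cc(=O)c3c(OC)cc(OC)cc3n2S(=O)(=O)c2ccc([N+](=O)[O-])cc2)cc1`: 17100 nM

Compound 3 holds the higher of the two numbers that are known, and compound 1 sits next to it with a number that is within the usual scatter of it, so the two cannot be ordered. For the measured compounds named here, the one step measured so far, an at least 2.3-fold higher number from compound 1 to compound 2 (0.37 log units; beyond the scatter), is at least modest and ends at the limit (the limit of > 37900 nM in this assay, at which 1 of the 3 values shown sits).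

Compound 4, `COc1ccc(-c2cc(=O)c3c(OC)cc(OC)cc3n2S(=O)(=O)c2cccc(Br)c2)cc1`, differs from compound 3 in one place: 3-bromophenyl in place of 4-nitrophenyl on a sulfonyl sulfur. Going by the values given here, the change sits on the sulfonyl sulfur, a part of the molecule that none of the measured steps touches; the only measured step concerns the aromatic nitrogen and does not bear on this exchange. Among the compounds with values here, no step in this assay is therefore expected beyond the scatter, and compound 4 is estimated to stay close to compound 3, the expected step being a 1.0-fold lower number from compound 3 to compound 4 (0.00 log units; within the scatter). The estimated value for compound 4 in this assay is 17000 nM, with a range from 6000 nM to 50000 nM, and a real chance that only a limit is reported.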

Compound 4, half-maximal effective concentration: > 58600 nM
Compound 4: only a limit was reported (the forecaster's own chance of this, stated with the estimate: 30%); middle value at least 3.4-fold (0.53 log units) away from the limit.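

In this assay, for the compounds shown here, the exchange of 4-nitrophenyl for 3-bromophenyl on the sulfonyl sulfur gives an at least 3.4-fold higher number from compound 3 to compound 4 (0.53 log units; beyond the scatter), the first measured step at this place, and it lies beyond the scatter. The value of compound 4 is a limit of the assay and not a number: the limit of > 58600 nM in this assay, at which 1 of the 4 values shown sits. The aryl group on the sulfonyl sulfur is therefore not a silent part of these molecules, as the rest of the structure is shared and compound 3 gives a number in this assay while compound 4 gives only a limit; what in the exchange carries the step cannot be told from this one pair.

On these data alone, the exchange alters both the substituent and its place on the phenyl ring, and it stays open whether a 4-bromophenyl or a 3-nitrophenyl group on the sulfonyl sulfur would fall with compound 3 or with compound 4. Also open, as far as these compounds go, is how a 4-aminophenyl group or a plain methyl on the sulfonyl sulfur would read out, and so whether the number of compound 3 depends on the nitro group at all.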